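A few compounds are considered here, and "the series" means these few. Any claim that something is new, unique, unknown or untested is made for them only; others in the source may bear on it.

Measured in a functional assay on BT-474 cells (Homo sapiens) for antiproliferative activity, read by sulforhodamine B assay, with a stated time of 4 days; a lower number here means a stronger inhibitor of growth, a higher number a weaker inhibitor of growth:
- compound 1 `COc1cc(Cl)c(-c2nc(SCC(=O)NC(C)(C)C)nc3[nH]cc(C#N)c23)cc1OC`: 121 nM
- compound 2 `COc1cc(Cl)c(-c2nc(SCC(=O)NC(C)C)nc3[nH]cc(C#N)c23)cc1OC`: 81 nM
- compound 3 `COc1cc(Cl)c(-c2nc(SCC(=O)N3CCC3)nc3[nH]cc(C#N)c23)cc1O`: 21 nM

Compound 3 has the lowest number of the three, beyond the scatter from both others. Compound 4 `COc1cc(Cl)c(-c2nc(SCC(=O)N3CCC3)nc3[nH]cc(C#N)c23)cc1OC` differs from it in one place: methyl in place of hydrogen on an oxygen on an aromatic ring, or hydroxy to methoxy.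

Within the data shown here, no measured step covers this change. The only one, a 1.5-fold lower number from compound 1 to compound 2 (0.17 log units; within the scatter), lies in the amide group and gives no size to carry over. Compound 1 at 121 nM and compound 2 at 81 nM both have the methoxy, but their amides also differ from that of compound 3. They therefore give only a loose hint of a higher number in this assay.

For compound 4 the expected value is 45 nM, with an estimated range of 15 nM to 130 nM. This would be an expected 2.1-fold higher number from compound 3 to compound 4 (0.33 log units; beyond the scatter).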

Compound 4, concentration for 50% growth inhibition: 31 nM
For compound 4 the middle estimate is 1.5-fold (0.16 log units) above the measured one, and the stated range covers the measured number.
By their numbers in this assay, from the lowest: compounds 3 and 4 (each within the scatter of the next); then compounds 2 and 1 (each within the scatter of the next).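

In this assay, hydroxy to methoxy on the aromatic ring gives a 1.5-fold higher number from compound 3 to compound 4 (0.17 log units; within the scatter), so with this amide the oxygen can carry hydrogen or methyl without a change beyond the scatter. With the methoxy kept, the amide can now be compared directly: azetidin-1-yl in place of isopropylamino gives a 2.6-fold lower number from compound 2 to compound 4 (0.42 log units; beyond the scatter), and azetidin-1-yl in place of (tert-butyl)amino gives a 3.9-fold lower number from compound 1 to compound 4 (0.59 log units; beyond the scatter). No measured evidence here bears on the reason for these steps.

From the compounds shown here alone, whether an ethyl group or a longer chain on this oxygen would fit the same picture remains open. Going by these compounds, the hydroxy also appears only with the azetidin-1-yl amide, so its step alongside the isopropylamino or (tert-butyl)amino amide is unknown.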